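Selenium to sulfur on the shared core

The source may report more compounds than this note shows. Statements on the series, on what has been measured and on what is new or still open speak of the compounds shown alone.

Compound 1, `CCCCC[Se]c1nc(NCc2ccccc2)c2ccccc2n1`, gives a value at the assay limit of > 100000 nM in a functional assay on HT-29 cells (Homo sapiens) for cytotoxicity, read by MTT assay, with a stated time of 72 h; a lower number here means a stronger inhibitor of growth, a higher number a weaker inhibitor of growth.
Compound 2, `CSc1nc(NCc2ccc([Se]C)cc2)c2ccccc2n1`, also sits at the limit, > 100000 nM.
Compound 3, `C[Se]c1nc(NCc2ccccc2)c2ccccc2n1`, gives 81000 nM.

Among the compounds with values here, compound 3 thus holds the only actual number recorded; the other two compounds sit at a limit. Within the data shown here, the step of an at least 1.2-fold lower number from compound 1 to compound 3 (0.09 log units; that floor lies within the scatter) is the single measured step, and it lies within the scatter. Compound 4, `CSc1nc(NCc2ccccc2)c2ccccc2n1`, differs from compound 3 by a group of 2 heavy atoms (1 carbon, 1 sulfur; no ring) in place of a group of 2 heavy atoms (1 carbon, 1 selenium; no ring), on an aromatic carbon. Among the measured compounds shown here, no measured step follows this exchange, and compound 2, which carries methylsulfanyl at that place, sits at the limit while also changed elsewhere. Because the limit of > 100000 nM in this assay, at which 2 of the 3 values shown sit, marks where most values lie, only a small step is expected in this assay, with a fair chance that compound 4 again reaches the limit. Compound 4 is estimated at 100000 nM, within 40000 nM to 300000 nM. The expected step is a 1.2-fold higher number from compound 3 to compound 4 (0.09 log units; within the scatter).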

Compound 4, concentration for total growth inhibition: > 100000 nM
Compound 4: no number, only a limit; the forecaster's own chance of this, stated with the estimate: 55%; the middle value sits exactly at the limit.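

Putting methylsulfanyl in place of the selenium group, on the aromatic carbon between two ring nitrogen atoms, gives an at least 1.2-fold higher number from compound 3 to compound 4 (0.09 log units; that floor lies within the scatter). The exchange therefore shows no step beyond the scatter in this assay, and the steps to compound 4 from compound 1 and compound 2 cannot be read. Selenium at this position thus cannot be said to matter, and the series offers few numbers for comparison: the limit of > 100000 nM in this assay, at which 3 of the 4 values shown sit.

From the compounds shown here alone, how far compound 4 lies past its limit stays open. So does whether an amine or a carboxylic acid at this position would give a measurable number.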